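Methyl to ethyl ester: expected effect on cell tolerance

A few compounds are considered here, and "the series" means these few. Any claim that something is new, unique, unknown or untested is made for them only; others in the source may bear on it.

The measured compounds and their values:
compound 1 `COC(=O)c1ccc(NC(=O)CSc2nncnc2-c2ccccc2Cl)c(Br)c1`, 59000 nM
compound 2 `O=C(CSc1nncnc1-c1cccc2ccccc12)N1CCc2ccccc2C1`, 13000 nM
compound 3 `O=C(CSc1nncnc1-c1ccccc1Cl)Nc1ccc(Cl)cc1Cl`, 51000 nM

In an ADME assay on MT4 cells (Homo sapiens) for cytotoxicity, read by MTT assay (a higher number here means that more compound is tolerated, a lower number that less compound is tolerated), compound 1 gives 59000 nM, and compound 3 gives 51000 nM, a number within the scatter of compound 1, so the two cannot be ranked. Compound 2 gives 13000 nM, which lies beyond the scatter below compound 1, so compound 1 stands at the well-tolerated end of these three.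

Compound 4 `CCOC(=O)c1ccc(NC(=O)CSc2nncnc2-c2ccccc2Cl)c(Br)c1` has not been measured. It differs from compound 1 by methyl in place of hydrogen on a saturated chain carbon bound to an oxygen next to a carbonyl group. Within the data shown here, with no measured pair showing this change, the expectation rests on the small size of the change alone. In this assay compound 4 is expected to give 55000 nM, between 25000 nM and 110000 nM, a step of a 1.1-fold lower number from compound 1 to compound 4 (0.03 log units; within the scatter) that is expected to stay within the scatter.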

Compound 4, half-maximal cytotoxic concentration: 69000 nM
Beside the measured number, compound 4's estimate is 1.3-fold (0.10 log units) below it; low and high end bracket the measured number.
By their numbers in this assay, from the lowest: compound 2; then compounds 3, 1 and 4 (each within the scatter of the next).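

Among these compounds, this is the first measured pair that differs only at this ester. In this assay the change from methoxycarbonyl to ethoxycarbonyl gives a 1.2-fold higher number from compound 1 to compound 4 (0.07 log units; within the scatter) and so cannot be told apart from repeat-measurement noise: at this position, adding one carbon leaves cell tolerance without a readable change. No supporting measurement is available to explain this result.

As far as these compounds go, whether a longer chain such as butyl would also leave tolerance unchanged remains open. So does the outcome of replacing the ester with a carboxylic acid or an amine.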